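Serum half-life in a thymidine series: compound 4 estimate

A few compounds are considered here, and "the series" means these few. Any claim that something is new, unique, unknown or untested is made for them only; others in the source may bear on it.

Measured compounds and their values in an ADME assay on the whole organism (serum) with Homo sapiens as the target; a lower number here means that the compound disappears faster, a higher number that the compound lasts longer:
- compound 1 `Cc1cn(C2CC(N=[N+]=[N-])C(COC(=O)OCCCCCCCCO)O2)c(=O)[nH]c1=O`: 0.0333 h
- compound 2 `Cc1cn(C2CC(N=[N+]=[N-])C(COC(=O)OCCCC(=O)OC(C)(C)C)O2)c(=O)[nH]c1=O`: 0.267 h
- compound 3 `Cc1cn(C2CC(N=[N+]=[N-])C(COC(=O)CCCC(=O)O)O2)c(=O)[nH]c1=O`: 30 h

Compound 1 sits at the lowest of the three numbers in this assay. Its nearest neighbour is compound 2, with an 8.0-fold higher number from compound 1 to compound 2 (0.90 log units; beyond the scatter); the furthest is compound 3, with a 900-fold higher number from compound 1 to compound 3 (2.95 log units; beyond the scatter).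

Compound 4 `Cc1cn(C2CC(N=[N+]=[N-])C(COC(=O)OCCCC(=O)O)O2)c(=O)[nH]c1=O` is not yet measured. Relative to compound 1 the change is carboxy in place of 5-hydroxypentyl on a saturated chain carbon, three bonds along the chain from an oxygen next to a carbonyl group.

For the measured compounds named here, two measured steps bear on this. The step to compound 2 swaps the same 5-hydroxypentyl for tert-butoxycarbonyl at the same place and gives a modest rise, an 8.0-fold higher number from compound 1 to compound 2 (0.90 log units; beyond the scatter). The step to compound 3, which also ends in a carboxylic acid at the end of the chain but changes the group on the carbonyl carbon as well, gives a large rise, a 900-fold higher number from compound 1 to compound 3 (2.95 log units; beyond the scatter). Compound 4 keeps the oxygen next to the carbonyl group of compound 1 while taking on the terminal carboxy, so a rise beyond the scatter is expected in this assay, of a size between those two steps: a 120-fold higher number from compound 1 to compound 4 (2.08 log units; beyond the scatter).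

Compound 4 is therefore estimated at 4 h, within a range of 0.7 h to 25 h.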

Compound 4, half-life: 13 h
Compound 4: middle estimate off by 3.3-fold (0.51 log units), on the low side; the range from low to high includes it.
By their numbers in this assay, from the lowest: compound 1; then compound 2; then compound 4; then compound 3.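

In this assay, carboxy in place of 5-hydroxypentyl on a saturated chain carbon, three bonds along the chain from an oxygen next to a carbonyl group, gives a 390-fold higher number from compound 1 to compound 4 (2.59 log units; beyond the scatter) with that oxygen still in place, so a large rise does not depend on the change on the carbonyl carbon seen in compound 3. The free acid is what goes with the long half-life here, not merely the loss of 5-hydroxypentyl: hydrogen in place of tert-butyl on an oxygen next to a carbonyl group gives a 49-fold higher number from compound 2 to compound 4 (1.69 log units; beyond the scatter) as a large step on its own. The group on the carbonyl carbon weighs less once the terminal carboxy is present, since 3-carboxypropoxy in place of 3-carboxypropyl gives a 2.3-fold lower number from compound 3 to compound 4 (0.36 log units; beyond the scatter) and that step is modest, though beyond the usual scatter.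

Nothing available bears on the cause of any of these steps. From the compounds shown here alone, whether an amide or an amine at the chain end, or a longer chain ahead of the carboxylic acid, would hold the half-life near that of compound 4 stays open.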